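A few compounds are considered here, and "the series" means these few. Any claim that something is new, unique, unknown or untested is made for them only; others in the source may bear on it.

Measured so far in an ADME assay on TZM cells (Homo sapiens) for cytotoxicity, read by CellTiter-Glo, with a stated time of 48 h; on this read-out higher numbers stand for lower toxicity in this test and lower numbers for higher toxicity in this test:
- compound 1 `COc1ccc(C2=Cc3ccc(F)cc3C(CC(C)=O)N2c2ccc(O)cc2)cc1`: 60500 nM
- compound 2 `COc1ccc(C2=Cc3ccc(F)cc3C(CC(C)=O)N2c2ccc([N+](=O)[O-])cc2)cc1`: 11200 nM
- compound 3 `COc1ccc(C2=Cc3ccc([N+](=O)[O-])cc3C(CC(C)=O)N2c2ccc(O)cc2)cc1`: 23500 nM

Of the three, compound 1 stands highest at 60500 nM, making it the least toxic in this test. Compound 4 `COc1ccc(C2=Cc3ccc(F)cc3C(CC(=O)CO)N2c2ccc(O)cc2)cc1` has not yet been measured. It departs from compound 1 by a single change, hydroxy in place of hydrogen on a saturated chain carbon bound to a carbonyl carbon, so that acetyl becomes (hydroxymethyl)carbonyl.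

Two measured steps are available, and both are modest. Nitro in place of hydroxy on an aromatic carbon gave a 5.4-fold lower number from compound 1 to compound 2 (0.73 log units; beyond the scatter), and nitro in place of fluoro on an aromatic carbon gave a 2.6-fold lower number from compound 1 to compound 3 (0.41 log units; beyond the scatter). For the measured compounds named here, neither step touches the 2-oxopropyl chain, and no measured compound varies that chain, so they bear on the new change only indirectly, as a guide to how far one substitution has moved the number in this small set. The direction of any shift at the chain cannot be read from them, and no step beyond the scatter is therefore expected, the estimate being a 1.2-fold lower number from compound 1 to compound 4 (0.07 log units; within the scatter). For compound 4 the expected value is 52000 nM, with an estimated range from 22000 nM to 100000 nM.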

Compound 4, half-maximal cytotoxic concentration: 47700 nM
Estimate against measurement, compound 4: 1.1-fold (0.04 log units) above, and the stated range covers the measured number.
By their numbers in this assay, from the lowest: compound 2; then compound 3; then compounds 4 and 1 (each within the scatter of the next).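

For the compounds shown here, the 2-oxopropyl chain varies for the first time with compound 4, and in this assay hydroxy in place of hydrogen on a saturated chain carbon bound to a carbonyl carbon gives a 1.3-fold lower number from compound 1 to compound 4 (0.10 log units; within the scatter). This shows that, on the core of compound 1, acetyl can become (hydroxymethyl)carbonyl with the number staying within the scatter, unlike the two nitro steps on aromatic carbons, a 5.4-fold lower number from compound 1 to compound 2 (0.73 log units; beyond the scatter) and a 2.6-fold lower number from compound 1 to compound 3 (0.41 log units; beyond the scatter), which both lie beyond it. No measured evidence bears on the reason for this result.

From the compounds shown here alone, this single pair cannot tell whether the chain tolerates other changes, so it remains open whether an amine, a carboxylic acid or a longer chain at this place would also stay within the scatter of compound 1. Also open is whether the same hydroxy change would read the same on compound 2 or compound 3, which both carry a nitro group, since the shown step was taken only on compound 1.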